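A few compounds are considered here, and "the series" means these few. Any claim that something is new, unique, unknown or untested is made for them only; others in the source may bear on it.

Measured so far in an in vitro ADME assay on microsomes from liver (Mus musculus) for pharmacokinetics, read by LC-MS; on this read-out lower numbers stand for slow clearance and higher numbers for fast clearance:
- Compound 1 `Cc1ccc2c(c1)nc(C)n2-c1ccc(C(=O)NC2CC2)s1`: > 72 mL/min/kg, a limit of the assay
- Compound 2 `Cc1cccc2nc(C)n(-c3ccc(C(=O)NC4CC4)s3)c12`: > 72 mL/min/kg, a limit of the assay
- Compound 3 `Cc1nc2cc(OC(F)(F)F)ccc2n1-c1ccc(C(=O)NC2CC2)s1`: 43 mL/min/kg

Among the compounds with values here, compound 3 stands apart as the only compound with an actual number, 43 mL/min/kg. The other two compounds sit at the limit of > 72 mL/min/kg in this assay, at which 2 of the 3 values shown sit.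

Compound 4 `Cc1nc2cc(C(F)(F)F)ccc2n1-c1ccc(C(=O)NC2CC2)s1` is made from compound 3 by one change: trifluoromethyl in place of trifluoromethoxy on an aromatic carbon. Trifluoromethyl takes the place of trifluoromethoxy on an aromatic carbon.

Within the data shown here, only one measured step bears on this change, an at least 1.6-fold lower number from compound 1 to compound 3 (0.22 log units; that floor lies within the scatter). It exchanged methyl for trifluoromethoxy, and its size is known only as a floor. Among the measured compounds shown here, no measured step exchanges trifluoromethoxy for trifluoromethyl directly, so the evidence is thin. No step beyond the scatter is expected in this assay, though a small drift toward faster clearance would not surprise. The expected step is a 1.2-fold higher number from compound 3 to compound 4 (0.07 log units; within the scatter). For compound 4 the estimated clearance is 50 mL/min/kg, with an expected range of 28 mL/min/kg to 72 mL/min/kg.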

Compound 4, clearance: > 72 mL/min/kg
Compound 4: a limit, no number; the forecaster's own chance of this, stated with the estimate: 15%; middle value at least 1.4-fold (0.15 log units) from the limit.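

In this assay compound 4 gives a limit and no number, so at this aromatic carbon trifluoromethyl reads like methyl and not like trifluoromethoxy: the limit of > 72 mL/min/kg in this assay, at which 3 of the 4 values shown sit.

Three fluorines on the group are therefore not enough to give a readable number here; among the groups shown at this position only trifluoromethoxy does, and the change that removes its oxygen gives an at least 1.6-fold higher number from compound 3 to compound 4 (0.22 log units; that floor lies within the scatter). That size is only a floor, and the step between compound 1 and compound 4 cannot be read, as both ends are limits.

A methoxy or a chlorine at this position would help show whether the oxygen or the fluorines of trifluoromethoxy matter more. Going by these compounds, how far compound 1 and compound 4 lie from each other stays open.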